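The compounds below may be only part of what the source reports. "The series", "measured", "known", "first", "only" and "open" are said of these compounds alone.

Measured so far in an ADME assay on J774.1 cells (Mus musculus) for cytotoxicity, read by resazurin assay, with a stated time of 48 h; a lower number here means a stronger inhibitor, a higher number a weaker inhibitor:
compound 1 `CCCCn1cc(C(=O)NCc2ccc(OC)c([N+](=O)[O-])c2)c(=O)c2cc(F)c(N3CCC(C(N)=O)CC3)cc21` — > 100000 nM
compound 2 `CCCn1cc(C(=O)NCc2ccccc2)c(=O)c2cc(F)c(N3CCC(C(N)=O)CC3)cc21` gives 43700 nM.

Compound 1 gives in this assay a limit of the assay and not a number, > 100000 nM; it sits at the limit of > 100000 nM in this assay, at which 1 of the 2 values shown sits. Among the measured compounds shown here, compound 2, with a propyl in place of the butyl and a plain benzyl on the amide, gives 43700 nM in this assay, a number inside the measured range; no step between compound 1 and compound 2 is worked out here, so only the two values themselves are noted.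

Compound 3 `CCCCn1cc(C(=O)NCc2ccco2)c(=O)c2cc(F)c(N3CCC(C(N)=O)CC3)cc21` is the next case on the shared core, differing from compound 1 by furan-2-yl in place of 4-methoxy-3-nitrophenyl on a saturated chain carbon bound to an amide-type nitrogen. A step from compound 1 to compound 3 in this assay is expected to run toward a measurable number, an at least 1.4-fold lower number from compound 1 to compound 3 (0.15 log units; that floor lies within the scatter), though a second limit is a real possibility. For compound 3 the estimate in this assay is 70000 nM, within 30000 nM to 200000 nM.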

Compound 3, half-maximal inhibitory concentration: 41400 nM
For compound 3 the middle estimate is 1.7-fold (0.23 log units) above the measured one; the measured number falls inside the stated range.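

In this assay compound 1 gives > 100000 nM, which is a limit of the assay and not a number. Among the compounds shown here, compound 3 gives a measured number, so furan-2-yl in place of 4-methoxy-3-nitrophenyl on a saturated chain carbon bound to an amide-type nitrogen is the first single-place change that can be read, and it gives an at least 2.4-fold lower number from compound 1 to compound 3 (0.38 log units; beyond the scatter). The step is only a floor on the size of the change, with one end resting on a limit: the limit of > 100000 nM in this assay, at which 1 of the 3 values shown sits.

As far as these compounds go, the whole 4-methoxy-3-nitrophenyl group changes in this step, so the separate parts played by the methoxy, the nitro and the furan-2-yl remain open. Also open, from the compounds shown here alone, is how a pyridine or a carboxylic acid at this place, or a pentyl in place of the butyl, would read in this assay.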